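The compounds below may be only part of what the source reports. "The series", "measured", "known", "first", "only" and "open" are said of these compounds alone.

Measured compounds in a functional assay on NCI-H226 cells (Homo sapiens) for cytotoxicity, read by sulforhodamine B assay, with a stated time of 48 h; on this read-out higher numbers stand for weaker inhibition of growth and lower numbers for stronger inhibition of growth:

- compound 1, `Nc1nc(Cl)c2ncn(Cc3ccccc3CCl)c2n1`: 2630 nM
- compound 2, `Nc1nc(Cl)c2ncn(Cc3cccc(CCl)c3)c2n1`: 10700 nM

Of the compounds shown here, two have been measured in this assay. Compound 1 gives 2630 nM, the lowest of the two numbers. Compound 2 gives 10700 nM, a higher number, and the gap between the two values lies beyond the scatter. Among the compounds with values here, no single-point step between the two measured compounds is available, so only the two values themselves are stated here; they share the core of compound 1 and differ in where the chloromethyl-bearing benzyl group is substituted.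

Compound 3, `ClCc1ccccc1Cn1cnc2c(Cl)ncnc21`, is not yet measured in this assay. It differs from compound 1 in one place: hydrogen in place of amino on an aromatic carbon. Within the data shown here, no step of this kind is available among the measured compounds, so the direction of the change rests on expectation alone. The amino group is removed without replacement, and the expectation is a step toward weaker growth inhibition, of modest size, possibly within the scatter. The expected step from compound 1 to compound 3 is a 1.9-fold higher number from compound 1 to compound 3 (0.28 log units; within the scatter). Compound 3 is therefore estimated at 5000 nM, with a range from 1500 nM to 20000 nM.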

Compound 3, concentration for 50% growth inhibition: 4570 nM
Estimate against measurement, compound 3: 1.1-fold (0.04 log units) above, and the stated range covers the measured number.
By their numbers in this assay, from the lowest: compounds 1 and 3 (each within the scatter of the next); then compound 2.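

In this assay, within the data shown here, hydrogen in place of amino on an aromatic carbon, at the place between two ring nitrogen atoms, gives a 1.7-fold higher number from compound 1 to compound 3 (0.24 log units; within the scatter) and so provides the first reading for this position. The amino group can therefore be removed from this pair without a shift in the read-out that stands clear of the scatter, so on this pair the group is not required for growth inhibition in this range of values. No measurement on hand bears on why the two compounds read alike.

Still open, on these data alone, is whether another group on this aromatic carbon, such as a methylamino group, a hydroxyl or a methyl, would move the number beyond the scatter, since only amino and hydrogen have been compared here. Also open, as far as these compounds go, are whether the same exchange gives a similar step when the chloromethyl group sits as it does in compound 2, and whether replacing the chloromethyl group or the chloro group with a methyl would alter growth inhibition on the core of compound 1.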